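The source may hold more compounds than are shown below. What is called first, only, known or untested is meant among the compounds shown, and "the series" means these compounds.

Working notes on the series. Compound 1 `CNC(=O)c1cc(Oc2ccc(C(=O)/C=C/c3ccco3)cc2)ccn1` carries furan-2-yl on the chain. In a functional assay on HepG2 cells (Homo sapiens) for cytotoxicity, read by MTT assay, with a stated time of 72 h (on this read-out higher numbers stand for weaker inhibition and lower numbers for stronger inhibition), compound 1 gives "not determined" (no result reported), so no number places it. Going by the values given here, compound 2 `CNC(=O)c1cc(Oc2ccc(C(=O)/C=C/c3cccc(Br)c3)cc2)ccn1` is the only member with a result: in this assay compound 2 gives 2870 nM. Compound 3 `CNC(=O)c1cc(Oc2ccc(C(=O)/C=C/c3ccc(OC)cc3)cc2)ccn1` also lacks a result; in this assay compound 3 gives "not determined" (no result reported). Among the compounds with values here, no step between two measured compounds exists, so the numbers say nothing about how the group on the chain shifts the read-out.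

Compound 4 `CNC(=O)c1cc(Oc2ccc(C(=O)/C=C/c3cccc(Cl)c3Cl)cc2)ccn1` differs from compound 1 by 2,3-dichlorophenyl in place of furan-2-yl on a double-bonded chain carbon bound to a double-bonded chain carbon. Within the data shown here, with no number for compound 1, neither the size nor the direction of the step to compound 4 can be read from the data; the only anchor is compound 2, whose phenyl carries bromine, and compound 4 is expected to land close to compound 2, with any step in this assay expected to stay within the usual scatter, in no fixed direction. Compound 4 is therefore estimated at 2500 nM in this assay, within a range of 800 nM to 8000 nM.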

Compound 4, half-maximal inhibitory concentration: > 50000 nM
Compound 4 ended at the assay's limit; the forecaster's own chance of this, stated with the estimate: 15%; middle value at least 20-fold (1.30 log units) from the limit.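

The group on the double-bonded chain carbon now has a readable effect: with 2,3-dichlorophenyl in place of 3-bromophenyl, the series shows an at least 17-fold higher number from compound 2 to compound 4 (1.24 log units; beyond the scatter). A halogen-bearing phenyl at this position therefore does not by itself keep the read-out near that of compound 2, and the two halogenated phenyl groups are not interchangeable here. Compound 4 has no number in this assay, only a limit of the assay, so the true size of the step stays unknown: the limit of > 50000 nM in this assay, at which 1 of the 4 values shown sits.

The change swaps bromine for chlorine and adds a second chlorine at once, so the data cannot separate these two parts, and steps involving compound 1 or compound 3 cannot be read. Also open, as far as these compounds go, is how a phenyl carrying a dimethylamino group or a carboxylic acid would read in this assay.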